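A Dimethoxyphenyl Tail Gives Way to an Indole

A few compounds are considered here, and "the series" means these few. Any claim that something is new, unique, unknown or untested is made for them only; others in the source may bear on it.

Three compounds share a core and differ only in the aromatic group at the end of the amide chain. Compound 1 `CCCCC(N)c1cc(C(F)(F)F)ccc1N1CCN(C(=O)CCc2ccc(Cl)cc2Cl)CC1` gives 190 nM in an assay on HEK293 cells for displacement of a labelled ligand from Melanocortin receptor 4 (Homo sapiens); a higher number here means a weaker inhibitor, a lower number a stronger inhibitor. Compound 2 `CCC(C)[C@H](N)c1cc(C(F)(F)F)ccc1N1CCN(C(=O)CCc2ccc(OC)cc2Cl)CC1` gives 57 nM in this assay. Compound 3 `COc1ccc(OC)c(CCC(=O)N2CCN(c3ccc(C(F)(F)F)cc3[C@@H](N)CC(C)C)CC2)c1` gives 2500 nM in this assay, the highest of the three numbers; compound 1 stands nearest to it and compound 2 furthest, and both gaps lie beyond the scatter, so compound 3 is the weakest of the three in this assay.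

Compound 4 `Cc1[nH]c2ccccc2c1CCC(=O)N1CCN(c2ccc(C(F)(F)F)cc2[C@@H](N)CC(C)C)CC1` has not yet been measured. It differs from compound 3 in one place: 2-methyl-1H-indol-3-yl in place of 2,5-dimethoxyphenyl on a saturated chain carbon, two bonds along the chain from a carbonyl carbon. Among the measured compounds shown here, no measured pair shows this change, so the size of the step has to be estimated from the spread among the three measured compounds alone. Because compound 3 gives 2500 nM while compound 1 and compound 2 give markedly lower numbers with other aromatic groups in the same place, the expectation is that moving away from the dimethoxyphenyl group will lower the number, with a step of a 4.2-fold lower number from compound 3 to compound 4 (0.62 log units; beyond the scatter) in this assay. Compound 4 is therefore expected to give 600 nM in this assay, within a range of 120 nM to 3000 nM.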

Compound 4, inhibition constant: 1600 nM
Compound 4: the middle estimate sits 2.7-fold (0.43 log units) below what was measured; low and high end bracket the measured number.
By their numbers in this assay, from the lowest: compound 2; then compound 1; then compounds 4 and 3 (each within the scatter of the next).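

In this assay, among the compounds shown here, putting 2-methyl-1H-indol-3-yl in place of 2,5-dimethoxyphenyl on a saturated chain carbon, two bonds along the chain from a carbonyl carbon, gives a 1.6-fold lower number from compound 3 to compound 4 (0.19 log units; within the scatter), so the first pair that differs in one place only shows no change that can be told from the scatter. The group that leaves has 0 hydrogen-bond donors and 2 hydrogen-bond acceptors, the group that enters has 1 hydrogen-bond donor, 0 hydrogen-bond acceptors and an added five-membered aromatic ring, and both have 10 heavy atoms, yet this exchange leaves the number within the scatter. Nothing among the data shown offers an explanation for this result.

Compound 1 at 190 nM and compound 2 at 57 nM differ from compound 3 in more than one place, so the compounds shown do not settle whether their aromatic groups or their other differences separate them from compound 3. From the compounds shown here alone, how a plain 1H-indol-3-yl group, without the methyl, or a pyridine ring would read at this place on the chain also stays open.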